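Swapping amino for hydroxy on the side chain

The source may hold more compounds than are shown below. What is called first, only, known or untested is meant among the compounds shown, and "the series" means these compounds.

Measured in a functional assay on BXPC-3 cells (Homo sapiens) for antiproliferative activity, read by MTT assay, with a stated time of 24 h; a lower number here means a stronger inhibitor, a higher number a weaker inhibitor:
compound 1 `CCn1c(C(=O)N[C@H](C)C(=O)OC)ccc1C(CC)(CC)c1ccc(OCS(=O)(=O)c2ccccc2)c(C)c1`: > 50000 nM (a limit, not a number)
compound 2 `CCn1c(C(=O)NCCN)ccc1C(CC)(CC)c1ccc(OCS(=O)(=O)c2ccccc2)c(C)c1`: 6430 nM

For the measured compounds named here, compound 2 holds the only true number so far, since the reading for compound 1 is a limit of the assay. The next compound, compound 3 `CCn1c(C(=O)NCCO)ccc1C(CC)(CC)c1ccc(OCS(=O)(=O)c2ccccc2)c(C)c1`, keeps the shared core and the amide and alters one group: hydroxy in place of amino on a saturated chain carbon, two bonds along the chain from an amide-type nitrogen. In words, this is hydroxy in place of amino on a saturated chain carbon, two bonds along the chain from an amide-type nitrogen.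

Going by the values given here, only one measured step bears on this: an at least 7.7-fold lower number from compound 1 to compound 2 (0.89 log units; beyond the scatter). It brought in 2-aminoethyl in place of 1-(methoxycarbonyl)ethyl on an amide-type nitrogen, and it starts from a limit. That step shows that this side chain can move the number beyond the scatter, but it cannot separate the amino group from the rest of the chain. Compound 3 keeps the chain and gives up the amino group, so part of that gain is expected to be lost. The expected change is a 2.8-fold higher number from compound 2 to compound 3 (0.45 log units; beyond the scatter), towards a higher number and a weaker inhibitor. For compound 3 the estimated value is 18000 nM, with an expected range from 7000 nM to 50000 nM.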

Compound 3, half-maximal inhibitory concentration: 19900 nM
The estimate for compound 3 lay 1.1-fold (0.04 log units) below the measured number, and the stated range covers the measured number.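

Compounds 2 and 3 differ only at the end of the side chain, so this pair isolates the amino group, which the earlier step could not do. In this assay there is a 3.1-fold higher number from compound 2 to compound 3 (0.49 log units; beyond the scatter), so on this chain, on a saturated chain carbon two bonds along from an amide-type nitrogen, hydroxy is a modestly weaker choice than amino, though the effect of the swap is not large. On these data alone, the chain without its amino group still improves on 1-(methoxycarbonyl)ethyl, with an at least 2.5-fold lower number from compound 1 to compound 3 (0.40 log units; beyond the scatter), which suggests that the gain seen earlier does not rest on the amino group alone, although the true size of that gain stays unknown, as compound 1 gives only a limit and not a number: the limit of > 50000 nM in this assay, at which 1 of the 3 values shown sits.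

The compounds shown leave open whether a dimethylamino group or a carboxylic acid at the same chain end would behave like amino, like hydroxy, or like neither. They also leave open how the number responds to a longer chain, such as 3-aminopropyl or 3-hydroxypropyl, carrying these same end groups.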